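Dichlorobenzyl variant of compound 1 in HEL cytotoxicity

This account rests on a few compounds, and the source may have more. Where it says the series, first, only, none or still open, it means among the compounds named here.

Compound 1 `O=S1(=O)N=C(OCc2ccccc2)c2ccccc2N1Cc1ccccc1` is the benzyl member of the shared core. In a functional assay on HEL cells (Homo sapiens) for inhibition (on this read-out higher numbers stand for lower toxicity in this test and lower numbers for higher toxicity in this test), compound 1 reaches only a limit of the assay, > 200000 nM. Compound 2 `O=C1c2ccccc2N(Cc2ccccc2Cl)S(=O)(=O)N1Cc1ccccc1` gives 88000 nM in this assay. Compound 3 `C#CCOCN1c2ccccc2C(=O)N(Cc2ccccc2)S1(=O)=O` gives a limit of the assay, > 140000 nM, in this assay. Among the measured compounds shown here, the single measured step, an at least 1.5-fold higher number from compound 2 to compound 3 (0.20 log units; that floor lies within the scatter), concerns another change and stays within the scatter. For the measured compounds named here, no measured step covers the change to compound 4 `O=S1(=O)N=C(OCc2ccccc2)c2ccccc2N1Cc1ccc(Cl)c(Cl)c1`, which is 3,4-dichlorophenyl in place of phenyl on a saturated chain carbon bound to a sulfonamide nitrogen in a ring. Going by the values given here, compound 2, the only member bearing a 2-chlorophenyl group, is also the only one that returns a number, 88000 nM, and not a limit. Compound 4 is therefore expected near 100000 nM, with a range from 30000 nM to 200000 nM. This amounts to an expected step of an at least 2.0-fold lower number from compound 1 to compound 4 (0.30 log units; that floor lies within the scatter).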

Compound 4, half-maximal cytotoxic concentration: > 200000 nM
Compound 4 was reported as a limit; the forecaster's own chance of this, stated with the estimate: 40%; middle value at least 2.0-fold (0.30 log units) away from the limit.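

Among the compounds shown here, compound 1 and compound 4 both stand at the same limit of the assay, so no step between them can be read: the limit of > 200000 nM in this assay, at which 2 of the 4 values shown sit. From the compounds shown here alone, what 3,4-dichlorophenyl in place of phenyl does in this assay stays open.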